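Replacing the Ether of Compound 3 by Chloro

The source may report more compounds than this note shows. Statements on the series, on what has been measured and on what is new or still open speak of the compounds shown alone.

The measured compounds are:
Compound 1 `CCOc1cc2oc(=O)n(CCC(=O)O)c2cc1Cl` gives 81.6% in an ADME assay on the whole organism (plasma, Rattus norvegicus, strain Han-Wistar) for protein binding, read by LC-MS, at a dose of 1 mg/kg by the intravenous route.
Compound 2 `Cc1ccc([C@@H](C)Oc2cc3onc(CCC(=O)O)c3cc2Cl)nn1` gives 93.3% in this assay.
Compound 3 `O=C(O)CCn1c(=O)oc2cc(OCC3CC3)c(Cl)cc21` gives 90.2% in this assay.

Compound 3 holds the second highest of the three unbound fractions in this assay. Its nearest neighbour is compound 2 and its furthest is compound 1, and both gaps lie within the scatter, so the three measured compounds cannot be told apart on these numbers. Within the data shown here, the only step between two measured compounds that differ in one place is a 1.9-fold lower unbound fraction from compound 1 to compound 3 (0.27 log units; within the scatter), and it too lies within the scatter.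

Compound 4 `O=C(O)CCn1c(=O)oc2cc(Cl)c(Cl)cc21` is the next compound. Compared with compound 3 the change is chloro in place of cyclopropylmethoxy on an aromatic carbon. Among the measured compounds shown here, the step from compound 1 to compound 3 altered only the saturated chain of the same ether, which now leaves altogether; no measured step exchanges such an ether for a chloro group, so the guidance for compound 4 is thin. Because a 1.9-fold lower unbound fraction from compound 1 to compound 3 (0.27 log units; within the scatter) stayed within the scatter, compound 4 is expected to stay close to compound 3 as well, with a 1.1-fold lower unbound fraction from compound 3 to compound 4 (0.04 log units; within the scatter). Compound 4 is therefore estimated at 91% in this assay, with a range from 84% to 96%.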

Compound 4, plasma protein binding in the plasma assay: 91.7%
Compound 4: the middle estimate sits 1.1-fold (0.04 log units) (unbound fraction) above what was measured, and the stated range covers the measured number.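

In the plasma assay, this position now has a readable exchange: a 2.2-fold lower unbound fraction from compound 1 to compound 4 (0.35 log units; beyond the scatter), a modest step, whereas a 1.2-fold lower unbound fraction from compound 3 to compound 4 (0.07 log units; within the scatter), so the chloro group can be told apart from ethoxy but not from cyclopropylmethoxy on these numbers. In a physicochemical assay for solubility, with a stated time of 24 h (on this read-out higher numbers stand for higher solubility and lower numbers for lower solubility), compound 3 gives > 2060 ug/mL, which is a limit of the assay. In the physicochemical assay, compound 4 gives 270 ug/mL. The exchange of chloro in place of cyclopropylmethoxy could not be read in the plasma assay. From the compounds shown here alone, in the physicochemical assay, the same exchange shows an at least 7.6-fold lower number from compound 3 to compound 4 (0.88 log units; beyond the scatter), a step that is beyond the scatter and whose full size stays unknown because one of its two values is a limit: the limit of > 2060 ug/mL in the physicochemical assay, at which 1 of the 2 values shown sits.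

The compounds shown leave open how an amine or a hydroxyl group on this aromatic carbon would behave in the plasma assay and in the physicochemical assay. They also leave open whether a longer ether chain at this position would stay within the scatter of compound 3 in the plasma assay, and where the solubility of compound 3 actually lies.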